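The source may hold more compounds than are shown below. What is called first, only, known or untested is meant among the compounds shown, and "the series" means these compounds.

The compounds in this set share one core, seen in compound 1, `COc1cc2c(=O)c(C(=O)c3ccc(C)cc3)cn(Cc3ccc(N)cc3)c2cc1OC`, and differ only in the group carried on the nitrogen of that core. In an ADME assay on Huh-7 cells (Homo sapiens) for cytotoxicity (a higher number here means a weaker inhibitor of growth, a lower number a stronger inhibitor of growth), compound 1 gives "not active" (no number reported). Compound 2, `COc1cc2c(=O)c(C(=O)c3ccc(C)cc3)cn(Cc3ccc(C(C)C)cc3)c2cc1OC`, gives in this assay 15500 nM, a number that marks it as a weak inhibitor of growth. Compound 3, `COc1cc2c(=O)c(C(=O)c3ccc(C)cc3)cn(Cc3ccccc3)c2cc1OC`, gives in this assay "not active" (no number reported). Compound 3 thus stands without a number, just as compound 1 does, and compound 2 is the only one of the three for which a figure was reported at all.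

Compound 4, `COc1cc2c(=O)c(C(=O)c3ccc(C)cc3)cn(CC3CC3)c2cc1OC`, has not yet been measured. It differs from compound 3 in one place: cyclopropyl in place of phenyl on a saturated chain carbon bound to an aromatic nitrogen. For the measured compounds named here, no measured pair in this set shows the effect of such a change, so the step can only be judged from the surroundings. Going by the values given here, compound 3 shows no measurable growth inhibition, and compound 2 with 15500 nM is the strongest inhibitor here only in the sense of being the sole compound with a reported number. A step of no more than the usual scatter is expected, most likely leaving compound 4 inactive or weakly active. The estimate for compound 4 in this assay is 40000 nM, with a range from 10000 nM to 150000 nM.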

Compound 4, concentration for 50% growth inhibition: "not active" (no number reported)
Nothing numeric was reported for compound 4, and the estimate cannot be compared.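

In this assay compound 3 gives "not active" (no number reported) and compound 4 gives "not active" (no number reported) with no number on either side, so no step can be read between them. Nothing available here explains this result. The compounds shown leave open whether replacing phenyl with cyclopropyl changes growth inhibition at all.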